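A few compounds are considered here, and "the series" means these few. Any claim that something is new, unique, unknown or untested is made for them only; others in the source may bear on it.

Measured so far in an assay on isolated protein for binding affinity to somatostatin receptor type 3 (Homo sapiens); on this read-out higher numbers stand for weaker binding and lower numbers for tighter binding:
compound 1 `COC(=O)c1cc(CC(C)CN2C[C@H]3CCCC[C@H]3[C@@H](C(=O)N3CCN(c4ccc([N+](=O)[O-])cc4)CC3)C2)cc(C(=O)OC)c1` gives 107 nM
compound 2 `COC(=O)c1cc(C[C@@H](C)CN2C[C@@H]3CCCC[C@@H]3[C@H](C(=O)N3CCN(c4ccc([N+](=O)[O-])cc4)CC3)C2)cc(C(=O)OC)c1` gives 2.24 nM
compound 3 `C[C@@H](Cc1ccc2ocnc2c1)CN1C[C@@H]2CCCC[C@@H]2[C@H](C(=O)N2CCN(c3ccc(F)c(F)c3)CC2)C1` gives 11 nM

Compound 3 holds the second highest of the three numbers: compound 2 lies below it, beyond the scatter, and compound 1 lies above it, also beyond the scatter. Compound 3 carries the same drawn configuration at all four stereocentres as compound 2.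

The next compound is compound 4 `C[C@@H](Cc1ccc2nccnc2c1)CN1C[C@@H]2CCCC[C@@H]2[C@H](C(=O)N2CCN(c3ccc(F)c(F)c3)CC2)C1`, not yet measured. It differs from compound 3 only in the aromatic group on the side chain: quinoxalin-6-yl in place of 1,3-benzoxazol-5-yl on a saturated chain carbon, three bonds along the chain from an amine nitrogen in a ring. Among the measured compounds shown here, the single measured step in this set, a 48-fold lower number from compound 1 to compound 2 (1.68 log units; beyond the scatter), concerns configuration alone, the two compounds having identical atoms and bonds (the fact that one of compounds 1 and 2 is drawn with a defined configuration and the other without, at the place where they differ); it therefore gives no guidance on exchanging one bicyclic aromatic ring for another. For the measured compounds named here, no measured pair shows that kind of change. The leaving and entering groups are of similar size and, as counted, carry the same number of acceptors and no donors, so the step is expected to be small, within or close to the scatter, in no firm direction: a 1.1-fold higher number from compound 3 to compound 4 (0.04 log units; within the scatter). Compound 4 is estimated at 12 nM, with a range from 4 nM to 40 nM.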

Compound 4, dissociation constant: 10.7 nM
For compound 4 the middle estimate is 1.1-fold (0.05 log units) above the measured one; the range from low to high includes it.
By their numbers in this assay, from the lowest: compound 2; then compounds 4 and 3 (each within the scatter of the next); then compound 1.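

In this assay, putting quinoxalin-6-yl in place of 1,3-benzoxazol-5-yl on a saturated chain carbon, three bonds along the chain from an amine nitrogen in a ring, gives a 1.0-fold lower number from compound 3 to compound 4 (0.01 log units; within the scatter). Among the compounds shown here, this is the first measured exchange of one aromatic group for another at this place, and the read-out does not separate the two groups, even though the five-membered aromatic ring with 2 hetero atoms gives way to a six-membered one and the group goes from 9 to 10 heavy atoms. The one available observation on these compounds concerns configuration in a different pair and has no bearing on this exchange.

From the compounds shown here alone, what remains open is whether this place is equally undemanding towards groups of another type, such as a plain phenyl ring, a single pyridine ring or a carboxylic acid, since both groups compared here are bicyclic aromatic systems without a donor. Also open, going by these compounds, is whether the large step seen with configuration, a 48-fold lower number from compound 1 to compound 2 (1.68 log units; beyond the scatter), would carry over to compounds bearing the 1,3-benzoxazol-5-yl or quinoxalin-6-yl group.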